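Dipropylamino in place of (4-bromophenyl)amino: notes on compound 4

The source may report more compounds than this note shows. Statements on the series, on what has been measured and on what is new or still open speak of the compounds shown alone.

In a functional assay on MGC-803 cells (Homo sapiens) for inhibition, read by sulforhodamine B assay (on this read-out lower numbers stand for stronger inhibition and higher numbers for weaker inhibition), compound 1 (`O=C1C=C(Nc2ccccc2F)C(=O)c2c1nc1n2[C@H]2OC[C@@H](O)[C@H]2OC1`) gives 2080 nM, compound 2 (`COc1ccccc1NC1=CC(=O)c2nc3n(c2C1=O)[C@H]1OC[C@@H](O)[C@H]1OC3`) gives 1630 nM and compound 3 (`O=C1C=C(Nc2ccc(Br)cc2)C(=O)c2c1nc1n2[C@H]2OC[C@@H](O)[C@H]2OC1`) gives 1010 nM. Compound 3 stands apart from compound 1 by a 2.1-fold lower number from compound 1 to compound 3 (0.31 log units; beyond the scatter), a modest step, but it is not separated from compound 2, given a 1.6-fold lower number from compound 2 to compound 3 (0.21 log units; within the scatter).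

Compound 4 (`CCCN(CCC)C1=CC(=O)c2nc3n(c2C1=O)[C@H]1OC[C@@H](O)[C@H]1OC3`) carries dipropylamino in place of (4-bromophenyl)amino on a double-bonded ring carbon.

The measured steps bear on this change only loosely. Besides the two above, there is a 1.3-fold lower number from compound 1 to compound 2 (0.11 log units; within the scatter). Among the compounds with values here, all three exchange one phenyl-bearing amine group for another, and none removes the ring or the hydrogen-bond donor, so the data contain no direct precedent. A modest move toward a higher number is expected, though with little support, and the estimated step in this assay is a 2.5-fold higher number from compound 3 to compound 4 (0.39 log units; beyond the scatter). For compound 4 the estimated value is 2500 nM, with an expected range of 800 nM to 8000 nM.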

Compound 4, half-maximal inhibitory concentration: > 16000 nM
Compound 4 gave a limit, no number (the forecaster's own chance of this, stated with the estimate: 10%); middle value at least 6.4-fold (0.80 log units) away from the limit.
By their numbers in this assay, from the lowest: compounds 3, 2 and 1 (each within the scatter of the next, the first and the last beyond it). At a limit, above all of these: compound 4.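

Compound 4 stands only as a limit, not as a number, in this assay: the limit of > 16000 nM in this assay, at which 1 of the 4 values shown sits. The largest exchange among the phenyl-bearing amine groups is a 2.1-fold lower number from compound 1 to compound 3 (0.31 log units; beyond the scatter), whereas dipropylamino in their place gives an at least 15-fold higher number from compound 3 to compound 4 (1.19 log units; beyond the scatter), an at least 9.8-fold higher number from compound 2 to compound 4 (0.99 log units; beyond the scatter) and an at least 7.6-fold higher number from compound 1 to compound 4 (0.88 log units; beyond the scatter). This position on the double-bonded ring carbon therefore tolerates exchange among the three phenyl-bearing amine groups shown, but not this replacement by dipropylamino.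

The exchange removes the aromatic ring and the hydrogen-bond donor together, and the compounds shown cannot tell which of the two losses carries the step. Propylamino would keep the donor without the ring, and methyl(phenyl)amino would keep the ring without the donor, so either group would separate the two.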